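Swapping methyl for chloro on the triazole-linked phenyl ring

A few compounds are considered here, and "the series" means these few. Any claim that something is new, unique, unknown or untested is made for them only; others in the source may bear on it.

Measured compounds:
compound 1, `Cc1ccccc1-n1cc(-c2ccccc2NS(=O)(=O)c2c[nH]c(=O)[nH]c2=O)nn1`, 3210 nM
compound 2, `O=c1[nH]cc(S(=O)(=O)Nc2cccc(-c3cn(-c4ccccc4F)nn3)c2)c(=O)[nH]1`, limit of > 20000 nM
compound 3, `Cc1ccccc1-n1cc(-c2ccc(NS(=O)(=O)c3c[nH]c(=O)[nH]c3=O)cc2)nn1`, 3130 nM

Of the compounds shown here, three sharing one core have been tested in a functional assay on A549 cells (Homo sapiens) for antiproliferative activity, read by MTT assay, with a stated time of 24 h; on this read-out higher numbers stand for weaker inhibition and lower numbers for stronger inhibition. Compound 1 `Cc1ccccc1-n1cc(-c2ccccc2NS(=O)(=O)c2c[nH]c(=O)[nH]c2=O)nn1` gives 3210 nM in this assay. Compound 2 `O=c1[nH]cc(S(=O)(=O)Nc2cccc(-c3cn(-c4ccccc4F)nn3)c2)c(=O)[nH]1` reaches only the limit of this assay, > 20000 nM; this is a limit, not a number. Compound 3 `Cc1ccccc1-n1cc(-c2ccc(NS(=O)(=O)c3c[nH]c(=O)[nH]c3=O)cc2)nn1` gives 3130 nM in this assay, the lowest of the two numbers shown, yet the number for compound 1 lies within the usual scatter of it, so the two cannot be told apart.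

Compound 4 `O=c1[nH]cc(S(=O)(=O)Nc2ccc(-c3cn(-c4ccccc4Cl)nn3)cc2)c(=O)[nH]1` has not yet been measured. It differs from compound 3 in one place: chloro in place of methyl on an aromatic carbon. No measured pair among these compounds shows this particular change, so there is no step to lean on. Chloro and methyl are groups of similar size, and the rest of the molecule is unchanged, so the expected step from compound 3 to compound 4 is small, a 1.0-fold lower number from compound 3 to compound 4 (0.02 log units; within the scatter), in no clear direction and within the scatter. On that basis compound 4 is expected to give about 3000 nM in this assay, with a plausible range from 1000 nM to 10000 nM.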

Compound 4, half-maximal inhibitory concentration: 2810 nM
Estimate against measurement, compound 4: 1.1-fold (0.03 log units) above; low and high end bracket the measured number.
By their numbers in this assay, from the lowest: compounds 4, 3 and 1 (each within the scatter of the next). At a limit, above all of these: compound 2.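

In this assay, the swap from 2-methylphenyl to 2-chlorophenyl gives a 1.1-fold lower number from compound 3 to compound 4 (0.05 log units; within the scatter), so compound 3 and compound 4 cannot be told apart. Among these compounds, until now, methyl was the only group seen at this place on an aromatic carbon, ortho to a large group, in this arrangement of the molecule. Compound 4 shows that the activity does not depend on methyl alone. A single chlorine atom can stand there and the reading stays within the usual variation between repeats. Nothing measured here explains why the two groups read alike.

From the compounds shown here alone, how a methoxy group, an amine or a carboxylic acid at this same place would read remains open, as does the plain phenyl ring with only hydrogen there. Also open, going by these compounds, is whether chloro in place of methyl would read the same way on compound 1, where the rest of the molecule is arranged differently from compound 3.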